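The source may hold more compounds than are shown below. What is called first, only, known or untested is meant among the compounds shown, and "the series" means these compounds.

Of the compounds shown here, three sharing one core have been measured in a functional assay on SW 1116 cells (Homo sapiens) for antiproliferative activity, read by MTT assay, with a stated time of 24 h; a lower number here means a stronger inhibitor, a higher number a weaker inhibitor. Compound 1 `O=[N+]([O-])c1ccccc1CSc1nnc(-c2ccc3c(c2)OCCO3)n1-c1ccccc1` gives 8300 nM, compound 2 `COc1cccc(CSc2nnc(-c3ccc4c(c3)OCCO4)n2-c2ccccc2)c1` gives 10100 nM, and compound 3 `Cc1ccccc1CSc1nnc(-c2ccc3c(c2)OCCO3)n1-c1ccccc1` gives 12700 nM. Compound 3 is separated from compound 2 by a 1.3-fold higher number from compound 2 to compound 3 (0.10 log units; within the scatter) and from compound 1 by a 1.5-fold higher number from compound 1 to compound 3 (0.18 log units; within the scatter), so on the numbers shown the three compounds cannot be told apart in this assay.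

Compound 4 `Fc1cccc(F)c1CSc1nnc(-c2ccc3c(c2)OCCO3)n1-c1ccccc1` differs from compound 3 by 2,6-difluorophenyl in place of 2-methylphenyl on a saturated chain carbon bound to a sulfur. Among the measured compounds shown here, the steps that bear on this change are those that also alter the group on the saturated chain carbon bound to a sulfur: a 1.2-fold higher number from compound 1 to compound 2 (0.09 log units; within the scatter) and a 1.3-fold higher number from compound 2 to compound 3 (0.10 log units; within the scatter). Neither moved the number beyond the scatter. The account therefore expects, for the step from compound 3 to compound 4, a 1.1-fold lower number from compound 3 to compound 4 (0.02 log units; within the scatter), that is, no step beyond the scatter in either direction. For compound 4 the estimate in this assay is 12000 nM, with a range from 6000 nM to 25000 nM.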

Compound 4, half-maximal inhibitory concentration: 9010 nM
Compound 4: middle estimate off by 1.3-fold (0.12 log units), on the high side; the range from low to high includes it.
By their numbers in this assay, from the lowest: compounds 1, 4, 2 and 3 (each within the scatter of the next).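

In this assay, the 2,6-difluorophenyl group on a saturated chain carbon bound to a sulfur gives a number that cannot be told apart from any of the three before it (a 1.4-fold lower number from compound 3 to compound 4 (0.15 log units; within the scatter); a 1.1-fold lower number from compound 2 to compound 4 (0.05 log units; within the scatter); a 1.1-fold higher number from compound 1 to compound 4 (0.04 log units; within the scatter)). A fourth group at this place, and the first that carries fluorine, thus extends the flat picture: among compounds 1 to 4, no change of the group at this place moves the number beyond the scatter, and none of these compounds goes against that. No measurement is available here that would explain this result.

On these data alone, all four compounds keep a substituted phenyl ring at this place, so it remains open whether an amine, a carboxylic acid or a longer chain there would shift the number beyond the scatter. As far as these compounds go, the rest of the shared core is identical throughout, so what a change elsewhere would do also remains open.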